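Furan for Thiophene in a Series Held at the Limit

The source may report more compounds than this note shows. Statements on the series, on what has been measured and on what is new or still open speak of the compounds shown alone.

Measured compounds:
compound 1 `Oc1ccccc1-c1cc(-c2ccsc2)cc(-c2ccccc2O)n1`: > 50000 nM
compound 2 `Oc1cccc(-c2cc(-c3ccsc3)cc(-c3ccccc3O)n2)c1`: > 50000 nM
compound 3 `Oc1ccc(-c2cc(-c3ccsc3)cc(-c3ccccc3O)n2)cc1`: > 50000 nM

In a functional assay on HCT-15 cells (Homo sapiens) for cytotoxicity, read by CCK-8 assay (on this read-out higher numbers stand for weaker inhibition and lower numbers for stronger inhibition), compound 1 gives > 50000 nM, and this is a limit of the assay, not a number. Compound 2 gives > 50000 nM in this assay, again a limit. Compound 3 gives > 50000 nM in this assay, also a limit. Because of the limit of > 50000 nM in this assay, at which 3 of the 3 values shown sit, none of the three steps among them can be read: a step that the two limits leave unreadable from compound 1 to compound 2, a step that the two limits leave unreadable from compound 1 to compound 3 and a step that the two limits leave unreadable from compound 2 to compound 3 all remain without a size. Compound 1 therefore stands nowhere in particular on the numbers shown; it sits at the same limit as the other two.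

Compound 4 `Oc1ccccc1-c1cc(-c2ccoc2)cc(-c2ccccc2O)n1` differs from compound 1 in one place: furan-3-yl in place of thiophen-3-yl on an aromatic carbon. Going by the values given here, no measured step touches this position, since all three measured steps move the hydroxyl on the hydroxyphenyl groups rather than the five-membered ring. The only guide is that every compound shown so far stays at the limit, and the exchange of one five-membered aromatic ring with one hetero atom for another of the same size gives no ground to expect a move beyond the scatter.

Compound 4 is therefore expected to sit at about 80000 nM, within 20000 nM to 400000 nM, most likely reported as a limit again. The expected step that the limit leaves unreadable from compound 1 to compound 4 is essentially none.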

Compound 4, half-maximal inhibitory concentration: > 50000 nM
Compound 4: a limit, no number; the forecaster's own chance of this, stated with the estimate: 85%; the middle value is on the limit's open side.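

The step from compound 1 to compound 4, furan-3-yl in place of thiophen-3-yl, cannot be read, as both compounds give only a limit in this assay and no number: the limit of > 50000 nM in this assay, at which 4 of the 4 values shown sit.

The compounds shown leave open whether the position of the hydroxyl or the choice of five-membered ring changes cytotoxicity in this assay at all.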